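The source may report more compounds than this note shows. Statements on the series, on what has been measured and on what is new or still open speak of the compounds shown alone.

Measured so far:
Compound 1, `COc1ccc(Cl)cc1N1CCN(CCNC(=O)c2cccnc2)CC1`: 2750 nM
Compound 2, `Cc1ccc(N2CCN(CCNC(=O)c3cccnc3)CC2)c(C)c1`: 1150 nM

Both compounds were tested in a functional assay for antagonist activity at Adrenergic receptor alpha-1 (Rattus norvegicus); a lower number here means tighter binding, a higher number weaker binding. Compound 1 gives the highest of the two numbers; its nearest neighbour, compound 2, gives 1150 nM, a lower number, and that gap lies beyond the usual scatter of repeated measurements. The unmeasured compound 3, `COc1ccc(Cl)cc1N1CCN(CCNC(=O)c2cc3ccccc3o2)CC1`, keeps the core of compound 1 and alters a single part of it: 1-benzofuran-2-yl in place of pyridin-3-yl on a carbonyl carbon. For the measured compounds named here, no pair of measured compounds differs in just one place, so the data hold nothing that shows how a change of this kind shifts this assay. The expectation therefore rests on the structural change alone: a moderate step in this assay, toward a lower number, is expected a 3.4-fold lower number from compound 1 to compound 3 (0.54 log units; beyond the scatter). Compound 3 is accordingly estimated at 800 nM, with a range from 150 nM to 4000 nM.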

Compound 3, dissociation constant: 2340 nM
Beside the measured number, compound 3's estimate is 2.9-fold (0.47 log units) below it; the measured number falls inside the stated range.
By their numbers in this assay, from the lowest: compound 2; then compounds 3 and 1 (each within the scatter of the next).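

The exchange of pyridin-3-yl for 1-benzofuran-2-yl, on a carbonyl carbon whose other neighbour is an amide-type nitrogen, gives in this assay a 1.2-fold lower number from compound 1 to compound 3 (0.07 log units; within the scatter). This single-place step shows that, on the core of compound 1, the number stays within the scatter when a six-membered aromatic ring with a nitrogen gives way to a group with more heavy atoms that carries an oxygen and an added carbon-only ring. No measurement at hand accounts for this result, so the reason for it remains unknown.

Going by these compounds, it remains open whether a plain phenyl, a thiophen-2-yl or a chain ending in an amine at the same carbonyl carbon would shift the number beyond the scatter. On these data alone, it is equally open whether 1-benzofuran-2-yl would behave the same way on the core of compound 2.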